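One Tail Change, Seen Once, Tried Again

The source may report more compounds than this note shows. Statements on the series, on what has been measured and on what is new or still open speak of the compounds shown alone.

Three compounds share a core and differ in the tail at the end of a chain hanging from an oxygen on an aromatic ring. In an assay on SH-SY5Y cells for inhibition of Voltage-dependent N-type calcium channel subunit alpha-1B (Homo sapiens), read by FLIPR and calcium flux, with stated times of 600 s and 300 s, in the presence of a further agent that is not named here (on this read-out lower numbers stand for stronger inhibition and higher numbers for weaker inhibition), compound 1 `CN(C)CCCOc1ccc(CN(C)c2nc3ccc(Oc4ccc(C(F)(F)F)cc4)cc3s2)cc1` gives 46000 nM, compound 2 `CN(Cc1ccc(OCCCNC(=N)N)cc1)c1nc2ccc(Oc3ccc(C(F)(F)F)cc3)cc2s1` gives 185000 nM, and compound 3 `N=C(N)NCCCOc1ccc(CNc2nc3ccc(Oc4cccc(C(F)(F)F)c4)cc3s2)cc1` gives 130000 nM. The change from compound 2 to compound 1 is a group of 3 heavy atoms (2 carbon, 1 nitrogen; no ring) in place of a group of 4 heavy atoms (1 carbon, 3 nitrogen; no ring), on a saturated chain carbon, three bonds along the chain from an oxygen on an aromatic ring, and it produced a 4.0-fold lower number from compound 2 to compound 1 (0.60 log units; beyond the scatter). How the core of compound 3 differs from the core of compound 2 is not broken down here. Compound 4 `CN(C)CCCOc1ccc(CNc2nc3ccc(Oc4cccc(C(F)(F)F)c4)cc3s2)cc1` has not yet been measured; it differs from compound 3 by a group of 3 heavy atoms (2 carbon, 1 nitrogen; no ring) in place of a group of 4 heavy atoms (1 carbon, 3 nitrogen; no ring), on a saturated chain carbon, three bonds along the chain from an oxygen on an aromatic ring, the same change as from compound 2 to compound 1. Resting on that earlier step, a drop of similar size is expected, a 3.9-fold lower number from compound 3 to compound 4 (0.60 log units; beyond the scatter). Compound 4 is therefore estimated to give 33000 nM in this assay, most likely between 12000 nM and 90000 nM.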

Compound 4, half-maximal inhibitory concentration: 51000 nM
Beside the measured number, compound 4's estimate is 1.5-fold (0.19 log units) below it, and the stated range covers the measured number.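

In this assay, the dimethylamino tail again lowers the number, with a 2.5-fold lower number from compound 3 to compound 4 (0.41 log units; beyond the scatter) on this second core. The two steps point the same way and agree in size within the scatter: the same change on two cores in this assay, a 4.0-fold lower number (0.60 log units; beyond the scatter) from compound 2 to compound 1 and a 2.5-fold lower number (0.41 log units; beyond the scatter) from compound 3 to compound 4, 1.6-fold (0.20 log units) apart, within the scatter of two such steps

So the change carried over between these two cores, but two pairs cannot show that it will hold on other cores, and they do not explain why the number falls.

On these data alone, it remains open whether another tail on the same chain, such as a primary amine or a morpholine, would lower the number further. As far as these compounds go, it is also open whether the same change would behave alike on a longer chain.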